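Methoxy for trifluoromethyl: cytotoxicity notes on the series

This account rests on a few compounds, and the source may have more. Where it says the series, first, only, none or still open, it means among the compounds named here.

Compound 1 `O=C(Nc1ccc(C(F)(F)F)cc1)c1cc(Cl)ccc1O` gives 2800 nM in an ADME assay on cells (Macrophage, Mus musculus) for cytotoxicity, read by resazurin assay, with a stated time of 3 days; a lower number here means a stronger inhibitor, a higher number a weaker inhibitor. Compound 2 `O=C(Nc1cc(C(F)(F)F)ccc1C(F)(F)F)c1cc(Cl)ccc1O` gives 6600 nM in this assay; the difference between the two cores is not broken down here. Compound 3 `COc1ccc(NC(=O)c2cc(Cl)ccc2O)cc1` sits at > 60000 nM in this assay, which is a limit of the assay and not a number. The change from compound 1 to compound 3 is methoxy in place of trifluoromethyl on an aromatic carbon and it produced an at least 21-fold higher number from compound 1 to compound 3 (1.33 log units; beyond the scatter), a step whose full size is hidden by the limit of > 60000 nM in this assay, at which 1 of the 3 values shown sits.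

Compound 4 `COc1ccc(C(F)(F)F)c(NC(=O)c2cc(Cl)ccc2O)c1` is not yet measured in this assay. It differs from compound 2 by methoxy in place of trifluoromethyl on an aromatic carbon, the same kind of change as from compound 1 to compound 3, though the place is not the same: here meta to a large group and para to a trifluoromethyl group, rather than para to a large group. Compound 4 is expected to show a 9.1-fold higher number from compound 2 to compound 4 (0.96 log units; beyond the scatter) in this assay, set beside the earlier at least 21-fold higher number from compound 1 to compound 3 (1.33 log units; beyond the scatter) and resting on compound 2 at 6600 nM as the starting point. For compound 4 the estimate in this assay is 60000 nM, within 15000 nM to 250000 nM, with a real chance that only a limit is returned.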

Compound 4, half-maximal inhibitory concentration: 4800 nM
Compound 4: middle estimate off by 13-fold (1.10 log units), on the high side, outside the stated range (below it).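

In this assay, methoxy in place of trifluoromethyl does not carry the same result from one core to the other: the same change on two cores in this assay, an at least 21-fold higher number (1.33 log units; beyond the scatter) from compound 1 to compound 3 and a 1.4-fold lower number (0.14 log units; within the scatter) from compound 2 to compound 4, at least 29-fold (1.46 log units) apart, beyond the scatter of two such steps. On the core of compound 2 the change gives a 1.4-fold lower number from compound 2 to compound 4 (0.14 log units; within the scatter), so no shift can be claimed there, but the two steps differ in both core and place, and these notes cannot separate the two; in compound 4 the methoxy is meta to a large group and para to a trifluoromethyl group. Going by these compounds, compound 3 stands at a limit of the assay and not at a number, so the full size of the earlier step remains unknown: the limit of > 60000 nM in this assay, at which 1 of the 4 values shown sits.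

On these data alone, two pairs set no rule for the series, and it remains open whether methoxy at one matching place on both cores would give matching steps. The compounds shown also leave open how an amine, a carboxylic acid or a longer chain in that place would read in this assay.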